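An aryl group replaces the amide arm on the triazole

The source may report more compounds than this note shows. Statements on the series, on what has been measured and on what is new or still open speak of the compounds shown alone.

This account concerns compound 2 `CCOC(=O)C1=Cc2ccccc2OC1(OCc1cn(CC(=O)Nc2cccc(F)c2)nn1)C(F)(F)F` and the not yet measured compound 4 `CCOC(=O)C1=Cc2ccccc2OC1(OCc1cn(-c2ccc(F)c([N+](=O)[O-])c2)nn1)C(F)(F)F`. In a functional assay on DU-145 cells (Homo sapiens) for inhibition, read by MTT assay, with a stated time of 24 h (on this read-out lower numbers stand for stronger inhibition and higher numbers for weaker inhibition), compound 2 gives > 150000 nM, which is a limit of the assay rather than a number. Compound 1 `CCOC(=O)C1=Cc2ccccc2OC1(OCc1cc(-c2ccc(OC)cc2)no1)C(F)(F)F` likewise gives > 150000 nM in this assay, again a limit. Compound 3 `CCOC(=O)C1=Cc2ccccc2OC1(OCc1cc(-c2ccc3ccccc3c2)no1)C(F)(F)F` gives 71800 nM in this assay. Among the measured compounds shown here, the one step with two numbers, an at least 2.0-fold lower number from compound 1 to compound 3 (0.31 log units; beyond the scatter), concerns a change on an aromatic carbon, a different place from the one changed here, and so does not bear directly on the present step. The change from compound 2 to compound 4 is 4-fluoro-3-nitrophenyl in place of ((3-fluorophenyl)carbamoyl)methyl on an aromatic nitrogen. For the measured compounds named here, the shared limit, (the limit of > 150000 nM in this assay, at which 2 of the 3 values shown sit), means no measured step in this assay bears on this change, and no direction can be drawn from the data. The step from compound 2 to compound 4 is therefore expected to be a number no higher from compound 2 to compound 4 (the limit leaves the size open), nothing beyond the scatter. Compound 4 is estimated at 150000 nM in this assay, between 60000 nM and 300000 nM, most likely reported again only as a limit.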

Compound 4, half-maximal inhibitory concentration: 13200 nM
For compound 4 the middle estimate is 11-fold (1.06 log units) above the measured one, outside the stated range (below it).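

In this assay the replacement gives an at least 11-fold lower number from compound 2 to compound 4 (1.05 log units; beyond the scatter), so the group on the aromatic nitrogen of the five-membered aromatic ring with 3 nitrogen does influence the read-out. The earlier step with a readable direction concerned a change on an aromatic carbon and said nothing about this nitrogen. The full size of the new step remains unknown because compound 2 stands at a limit of the assay, not at a number: the limit of > 150000 nM in this assay, at which 2 of the 4 values shown sit.

The change removes the amide hydrogen and carbonyl along with the chain that carries the 3-fluorophenyl ring, and it brings in a nitro group and a repositioned fluorine, so the compounds shown do not tell which of these parts accounts for the step. They also leave open how an amine in place of the nitro group, or an unsubstituted phenyl on the same nitrogen, would read.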